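Flipping the Stereocentre of a Weak Bile Acid Receptor Inhibitor

This account rests on a few compounds, and the source may have more. Where it says the series, first, only, none or still open, it means among the compounds named here.

Three compounds share one core, differing at a saturated chain carbon bound to an amide-type nitrogen in a ring and an aromatic carbon. In an assay on isolated protein for inhibition of Bile acid receptor (Homo sapiens), read by TR-FRET and LanthaScreen (on this read-out higher numbers stand for weaker inhibition and lower numbers for stronger inhibition), compound 1 `Cn1c([C@H](CC2CCCCC2)N2C(=O)CN(c3ccc(Oc4ccccc4)cc3)C2=O)nc2ccc(C(=O)O)cc21` gives 24400 nM, compound 3 `C[C@@H](c1nc2ccc(C(=O)O)cc2n1C)N1C(=O)CN(c2ccc(Oc3ccccc3)cc2)C1=O` gives 10400 nM, and compound 2 `CC(C)[C@@H](c1nc2ccc(C(=O)O)cc2n1C)N1C(=O)CN(c2ccc(Oc3ccccc3)cc2)C1=O` gives 175000 nM, the highest of the three; the steps of a 7.2-fold higher number from compound 1 to compound 2 (0.86 log units; beyond the scatter) and a 17-fold lower number from compound 2 to compound 3 (1.23 log units; beyond the scatter) place it well apart. Compound 4 `CC(C)[C@H](c1nc2ccc(C(=O)O)cc2n1C)N1C(=O)CN(c2ccc(Oc3ccccc3)cc2)C1=O` differs from compound 2 only in configuration: the two compounds have the same atoms and bonds and differ only in configuration as drawn: 1 of 1 stereo elements differ; a stereocentre at a saturated chain carbon is drawn S in compound 2 and R in compound 4. For the measured compounds named here, none of the measured steps changes configuration, so no step bears on this change, and its direction in this assay cannot be read from the data. Compound 4 is therefore expected near compound 2, at an estimated 100000 nM with a wide range from 15000 nM to 400000 nM, a step of a 1.8-fold lower number from compound 2 to compound 4 (0.24 log units; within the scatter).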

Compound 4, half-maximal inhibitory concentration: 119000 nM
Compound 4: the middle estimate sits 1.2-fold (0.08 log units) below what was measured, and the stated range covers the measured number.
By their numbers in this assay, from the lowest: compound 3; then compound 1; then compounds 4 and 2 (each within the scatter of the next).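

In this assay, inverting the stereocentre at the saturated chain carbon gives a 1.5-fold lower number from compound 2 to compound 4 (0.17 log units; within the scatter), so the two forms cannot be told apart. The earlier steps shown here changed the group on this carbon and moved the number beyond the scatter, whereas inversion with isopropyl in place does not, and the high number of compound 2 is not tied to its drawn configuration. This comparison isolates the stereocentre because no other part of the structure changes: the fact that compounds 2 and 4 differ only in the configuration as drawn

Going by these compounds, it remains open whether configuration counts for as little with the methyl of compound 3 or the cyclohexylmethyl of compound 1. On these data alone, how a chain ending in an amine would read on this carbon also remains open.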